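Ring size at the chain amine in the series

The source may report more compounds than this note shows. Statements on the series, on what has been measured and on what is new or still open speak of the compounds shown alone.

Compound 3 `Cc1cc(NCCN2CCCC2)nc2ccc(NC(=O)c3ccc(Cl)c(Cl)c3)cc12` carries a pyrrolidin-1-yl group on a saturated chain carbon, two bonds along the chain from a nitrogen on an aromatic ring. In a functional assay on SK-BR-3 cells (Homo sapiens) for antiproliferative activity, read by MTT assay, with a stated time of 72 h (on this read-out higher numbers stand for weaker inhibition and lower numbers for stronger inhibition), compound 3 gives 9530 nM, which stands second highest of the three numbers shown. Its nearest neighbour is compound 1 `Cc1cc(NCCN(C)C)nc2ccc(NC(=O)c3ccc(Cl)c(Cl)c3)cc12`, which in this assay gives 6670 nM; the step of a 1.4-fold higher number from compound 1 to compound 3 (0.15 log units; within the scatter) lies within the scatter. Furthest off is compound 2 `CCc1ccccc1C(=O)Nc1ccc2nc(N3CCN(CC)CC3)cc(C)c2c1`, which differs from the shared core in more than one place and in this assay gives 23900 nM, beyond the scatter from compound 3; no single-change step links it to the others.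

Compound 4 `Cc1cc(NCCN2CCCCC2)nc2ccc(NC(=O)c3ccc(Cl)c(Cl)c3)cc12` differs from compound 3 by piperidin-1-yl in place of pyrrolidin-1-yl on a saturated chain carbon, two bonds along the chain from a nitrogen on an aromatic ring. Within the data shown here, the only measured step bearing on this position is a 1.4-fold higher number from compound 1 to compound 3 (0.15 log units; within the scatter), where pyrrolidin-1-yl entered in place of dimethylamino and the number moved only within the scatter. Going from pyrrolidin-1-yl to piperidin-1-yl at the same place is a change of the same kind, so the expected step of a 1.0-fold higher number from compound 3 to compound 4 (0.02 log units; within the scatter) is small, with no direction beyond the scatter. For compound 4 in this assay the estimate is 10000 nM, with a range from 4500 nM to 25000 nM.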

Compound 4, half-maximal inhibitory concentration in the SK-BR-3 assay: 1800 nM
Estimate against measurement, compound 4: 5.6-fold (0.74 log units) above; measured number outside the range, below it.
By their numbers in the SK-BR-3 assay, from the lowest: compound 4; then compounds 1 and 3 (each within the scatter of the next); then compound 2.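

Among these compounds, in the SK-BR-3 assay the amine at the end of the chain is not the quiet position that the earlier compounds suggested: piperidin-1-yl stands apart from both other groups, with a 5.3-fold lower number from compound 3 to compound 4 (0.72 log units; beyond the scatter) and a 3.7-fold lower number from compound 1 to compound 4 (0.57 log units; beyond the scatter) against the step of a 1.4-fold higher number from compound 1 to compound 3 (0.15 log units; within the scatter) between the other two. A change from a five-membered to a six-membered non-aromatic ring at this place on the saturated chain carbon is therefore enough to move the number beyond the scatter, whereas dimethylamino and pyrrolidin-1-yl remain within the scatter of each other. In a physicochemical assay for lipophilicity, at pH 7.4 (a higher number here means a more lipophilic compound, a lower number a more polar compound), compound 3 gives 1.72 and compound 4 gives 2.72 and the stronger inhibition of compound 4 may go with its higher lipophilicity, though this single pair suggests the link and does not establish it: the measured distribution coefficient of compound 3, 1.72, and of compound 4, 2.72, a number 1.00 log units higher (beyond the scatter)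

Whether the step in inhibition follows the distribution coefficient or the six-membered ring itself stays open, as the one pair shown changes both together. Morpholin-4-yl or azepan-1-yl at the same place, or a longer chain carrying piperidin-1-yl, would help to separate the two readings.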